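The source may hold more compounds than are shown below. What is called first, only, known or untested is meant among the compounds shown, and "the series" means these compounds.

In a functional assay on K562 cells (Homo sapiens) for antiproliferative activity, with a stated time of 72 h (on this read-out lower numbers stand for stronger inhibition and higher numbers for weaker inhibition), the three measured compounds stand as follows.
Compound 1 `Cc1ccc(CNc2ncnc3c2ncn3[C@@H]2O[C@H](CO)[C@@H](O)[C@H]2O)cc1` gives > 166000 nM, which is a limit of the assay.
Compound 2 `OC[C@H]1O[C@@H](n2cnc3c(NCc4ccc(Cl)cc4Cl)ncnc32)[C@H](O)[C@@H]1O` gives 106000 nM.
Compound 3 `COc1ccc(CNc2ncnc3c2ncn3[C@@H]2O[C@H](CO)[C@@H](O)[C@H]2O)c(OC)c1` gives > 166000 nM, which is a limit of the assay.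

Compound 3 thus has no number of its own in this assay; it sits at the limit described in the limit of > 166000 nM in this assay, at which 2 of the 3 values shown sit, and only compound 2 returned a measured number. Accordingly the step of an at least 1.5-fold higher number from compound 2 to compound 3 (0.19 log units; that floor lies within the scatter) is read against that limit, while the step that the two limits leave unreadable from compound 1 to compound 3 joins two limits and cannot be sized. The step of an at least 1.5-fold lower number from compound 1 to compound 2 (0.19 log units; that floor lies within the scatter) is likewise small against its limit.

Compound 4 `Cc1cccc(CNc2ncnc3c2ncn3[C@@H]2O[C@H](CO)[C@@H](O)[C@H]2O)c1O` differs from compound 3 in one place: 2-hydroxy-3-methylphenyl in place of 2,4-dimethoxyphenyl on a saturated chain carbon bound to a nitrogen on an aromatic ring. Among the compounds with values here, no measured step brings a hydroxyl or a methyl onto this phenyl; the measured changes exchange 4-methylphenyl, 2,4-dichlorophenyl and 2,4-dimethoxyphenyl, and every one of the three compounds remains weak in this assay, at or near its limit. Nothing in these data points to a move beyond the scatter, so the step that this estimate means, an at least 1.1-fold lower number from compound 3 to compound 4 (0.04 log units; that floor lies within the scatter), is expected to stay within it. Compound 4 is therefore estimated at 150000 nM, with a range from 60000 nM to 400000 nM, and it may well return only a limit again.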

Compound 4, half-maximal inhibitory concentration: 18000 nM
Compound 4: the middle estimate sits 8.3-fold (0.92 log units) above what was measured, outside the stated range (below it).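

In this assay the aryl group on a saturated chain carbon bound to a nitrogen on an aromatic ring proved able to move the read-out beyond the scatter, which no earlier exchange had shown: replacing 2,4-dimethoxyphenyl with 2-hydroxy-3-methylphenyl gives an at least 9.2-fold lower number from compound 3 to compound 4 (0.96 log units; beyond the scatter), and replacing 2,4-dichlorophenyl with it gives a 5.9-fold lower number from compound 2 to compound 4 (0.77 log units; beyond the scatter). Replacing 4-methylphenyl gives an at least 9.2-fold lower number from compound 1 to compound 4 (0.96 log units; beyond the scatter), so compound 4, with every step to the others beyond the scatter, is the most potent of the four in this assay. Two of these steps are floors rather than sizes, since compound 1 and compound 3 each rest on a limit: the limit of > 166000 nM in this assay, at which 2 of the 4 values shown sit.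

The compounds shown do not separate the hydroxyl from the methyl, so it stays open whether either group alone would carry this gain or whether it needs both on the ring. As far as these compounds go, it also stays open whether an amine or a carboxylic acid in place of the hydroxyl, or a longer chain between the ring and the nitrogen, would keep, extend or lose the step.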